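Compound 2 to compound 4: exchange of the 1-hydroxyethyl group

The compounds below may be only part of what the source reports. "The series", "measured", "known", "first", "only" and "open" are said of these compounds alone.

In an ADME assay on MDBK cells (Bos taurus) for cytotoxicity, read by MTT assay, with a stated time of 96 h (a lower number here means that less compound is tolerated, a higher number that more compound is tolerated), compound 1 `COc1ccc(-c2nc3cc(C(C)O)ccc3[nH]2)c(OC)c1` gives > 100000 nM, a limit of the assay. Compound 2 `COc1ccc(-c2nc3cc(C(C)O)ccc3[nH]2)c(OC)c1OC` gives 60000 nM and compound 3 `C/C(=N\O)c1ccc2[nH]c(-c3ccc(Cl)cc3)nc2c1` gives 37000 nM, two values within the scatter of each other, so compound 2 stands level with compound 3. Compound 4 `COc1ccc(-c2nc3cc(/C(C)=N/O)ccc3[nH]2)c(OC)c1OC` differs from compound 2 at one place: a group of 4 heavy atoms (2 carbon, 1 nitrogen, 1 oxygen; no ring) in place of a group of 3 heavy atoms (2 carbon, 1 oxygen; no ring), on an aromatic carbon. For the measured compounds named here, the only measured step, an at least 1.6-fold lower number from compound 1 to compound 2 (0.22 log units; that floor lies within the scatter), is a methoxy in place of hydrogen, so it does not test this exchange. Compound 3 already carries the entering group and gives 37000 nM, which points to no large shift. The expected step is a 1.3-fold lower number from compound 2 to compound 4 (0.12 log units; within the scatter), which stays within the scatter. Compound 4 is estimated at 45000 nM, with an expected range of 18000 nM to 100000 nM.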

Compound 4, half-maximal cytotoxic concentration: > 100000 nM
Compound 4: only a limit was reported (the forecaster's own chance of this, stated with the estimate: 15%); middle value at least 2.2-fold (0.34 log units) away from the limit.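

At this aromatic carbon, the exchange of 1-hydroxyethyl for the group of 4 heavy atoms gives an at least 1.6-fold higher number from compound 2 to compound 4 (0.22 log units; that floor lies within the scatter) in this assay. This is the first step shown at this position, and it brings no sign of lower tolerance. The value of compound 4 is a limit of the assay, so the step is only a floor and its true size stays unknown: the limit of > 100000 nM in this assay, at which 2 of the 4 values shown sit.

Still open, from the compounds shown here alone, is how an amine or a carboxylic acid at this position on the shared core would read in this assay. A group that gives a number clearly lower than that of compound 2 would show how much this position matters.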